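This account rests on a few compounds, and the source may have more. Where it says the series, first, only, none or still open, it means among the compounds named here.

The shared core of this small series is a five-membered non-aromatic ring with one nitrogen and one sulfur, and all testing was done in a functional assay on MV cells (Homo sapiens) for inhibition, read by sulforhodamine B assay; a lower number here means a stronger inhibitor, a higher number a weaker inhibitor. Compound 1 `C#CC(=O)N1C(CCCC)SC[C@@H]1C(=O)OCC` carries a butyl group on a saturated ring carbon, and in this assay compound 1 gives 400 nM. Compound 2 `C#CC(=O)N1C(c2ccccc2F)SC[C@@H]1C(=O)OCC` carries a 2-fluorophenyl group at that same place, and in this assay compound 2 gives 1700 nM. Going by the values given here, compound 2 thus stands at the higher of the two numbers measured so far; its only neighbour is compound 1, and the one measured step is a 4.3-fold higher number from compound 1 to compound 2 (0.63 log units; beyond the scatter). Compound 3 `C#CC(=O)N1C(C(C)(C)C)SC[C@@H]1C(=O)OCC` has not yet been measured; it differs from compound 2 in one respect: tert-butyl in place of 2-fluorophenyl on a saturated ring carbon. The measured step bears on this change almost in reverse: putting 2-fluorophenyl in for butyl raised the number, so taking the aromatic ring out again in favour of an alkyl group is expected to lower it. Because the measured step of a 4.3-fold higher number from compound 1 to compound 2 (0.63 log units; beyond the scatter) concerns butyl and not tert-butyl, only a partial reversal is expected. For compound 3 the expected step is therefore a 2.8-fold lower number from compound 2 to compound 3 (0.45 log units; beyond the scatter). In this assay compound 3 is therefore estimated at 600 nM, within a range from 200 nM to 2000 nM.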

Compound 3, half-maximal inhibitory concentration: 900 nM
For compound 3 the middle estimate is 1.5-fold (0.18 log units) below the measured one, and the stated range covers the measured number.
By their numbers in this assay, from the lowest: compound 1; then compounds 3 and 2 (each within the scatter of the next).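

Replacing the aromatic ring with an alkyl group does not by itself bring a clear change at this ring carbon (a 1.9-fold lower number from compound 2 to compound 3 (0.28 log units; within the scatter)), so in this assay the 2-fluorophenyl and tert-butyl groups cannot be told apart. The earlier step from butyl to 2-fluorophenyl might have suggested that the aromatic ring alone set compound 2 apart, but the comparison of the two alkyl groups shows that the form of the alkyl group also counts (a 2.3-fold higher number from compound 1 to compound 3 (0.35 log units; beyond the scatter)). Having no ring at this place is therefore not enough to match compound 1 at 400 nM, and nothing available here explains either step.

The compounds shown leave open how the number would respond to a shorter chain such as methyl, to a longer chain such as hexyl, or to a plain phenyl group without fluorine, which would separate the effect of the ring from that of its fluorine. From the compounds shown here alone, it also remains open whether an amine or a carboxylic acid at the end of a chain on this ring carbon would be tolerated in this assay.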